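This account rests on a few compounds, and the source may have more. Where it says the series, first, only, none or still open, it means among the compounds named here.

Notes on the series

Compound 2 `COc1ccc2cc1Oc1ccc(cc1)C[C@H]1C(=O)N(C)[C@@H](C2)C(=O)N[C@H](C)C(=O)N[C@@H](C)C(=O)N(C)[C@@H](Cc2ccc(C)cc2)C(=O)N[C@@H](C)C(=O)N1C` and compound 1 `COc1ccc(C[C@H]2C(=O)N[C@@H](C)C(=O)N(C)[C@H]3Cc4ccc(cc4)Oc4cc(ccc4OC)C[C@@H](C(=O)N[C@H](C)C(=O)N[C@@H](CCCCO)C(=O)N2C)N(C)C3=O)cc1` share the same macrocyclic core, and both have been tested in a functional assay on P388 cells (Mus musculus) for cytotoxicity; a higher number here means a weaker inhibitor, a lower number a stronger inhibitor. Compound 2 gives 24 nM; compound 1 gives 219 nM, a higher number, and the gap between the two lies beyond the scatter of repeated measurements. Among the measured compounds shown here, of the two numbers, the one for compound 2 is the lower.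

Compound 3 `C/C=C/c1ccc(C[C@H]2C(=O)N[C@@H](C)C(=O)N(C)[C@H]3Cc4ccc(cc4)Oc4cc(ccc4OC)C[C@@H](C(=O)N[C@H](C)C(=O)N[C@@H](C)C(=O)N2C)N(C)C3=O)cc1` has not yet been measured in this assay. It differs from compound 2 in one place: prop-1-en-1-yl in place of methyl on an aromatic carbon. Cut one bond further out, the change reads 4-methylphenyl to 4-(prop-1-en-1-yl)phenyl, para to a large group on the ring.

For the measured compounds named here, no step between measured compounds bears on this change, so no direction can be read from the series. The step of a 1.3-fold higher number from compound 2 to compound 3 (0.10 log units; within the scatter) is expected to stay within the scatter, or at most slightly beyond it in either direction. Compound 3 is therefore estimated at 30 nM in this assay, with a range from 10 nM to 90 nM.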

Compound 3, half-maximal inhibitory concentration: 5.01 nM
Estimate against measurement, compound 3: 6.0-fold (0.78 log units) above, outside the stated range (below it).
By their numbers in this assay, from the lowest: compound 3; then compound 2; then compound 1.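

In this assay, among the compounds shown here, prop-1-en-1-yl in place of methyl on this aromatic carbon gives a 4.8-fold lower number from compound 2 to compound 3 (0.68 log units; beyond the scatter), the only step that isolates a single place. It shows that this position, para to a large group, responds to the choice of substituent, and that the larger group, with 3 heavy atoms against 1, is accepted here with a lower number rather than a higher one. Nothing at hand indicates why the number falls with this change.

Going by these compounds, whether the step follows the double bond or the added carbons stays open, and a saturated propyl group on the same carbon would separate the two. On these data alone, how far the position accepts other groups also stays open, whether a longer chain, an amine or a carboxylic acid.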